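Removing a Chloro from a Thiazolyl Ketone Sulfide

The source may hold more compounds than are shown below. What is called first, only, known or untested is meant among the compounds shown, and "the series" means these compounds.

Compound 1 `Cc1nc(-c2ccc(Cl)cc2)sc1C(=O)CSc1nc(N)c(C#N)c(-c2ccc(Cl)cc2)n1` was tested in a functional assay on U-87MG ATCC cells for antiproliferative activity against U-87 MG (Homo sapiens), read by MTT assay, with a stated time of 48 h, tested at 100 uM (a lower number here means a stronger effect, a higher number a weaker effect of the compound at the concentration tested), and gave 1.65%. Its companion compound 2 `COc1ccc(-c2nc(C)c(C(=O)CSc3nc(-c4ccc(OC)cc4)c(C#N)c(=O)[nH]3)s2)cc1` gave 11.5% in this assay, a gap that lies within the usual scatter of the measurement, so the two compounds stand together on the numbers shown. Compound 3 `Cc1nc(-c2ccccc2)sc1C(=O)CSc1nc(N)c(C#N)c(-c2ccc(Cl)cc2)n1` differs from compound 1 by hydrogen in place of chloro on an aromatic carbon. For the measured compounds named here, no measured pair shows the effect of this change, so the step of a number 6.4 percentage points higher from compound 1 to compound 3 (within the scatter) is an estimate only, and it is expected to be small, if anything toward a weaker effect. Compound 3 is therefore expected to give about 8% in this assay, between 0% and 30%.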

Compound 3, a percentage reported as activity, at one concentration (the size of the read-out at that concentration, not a potency): 17.1%
For compound 3 the middle estimate is 9.1 percentage points below the measured one; the measured number falls inside the stated range.
By their numbers in this assay, from the lowest: compounds 1, 2 and 3 (each within the scatter of the next, the first and the last beyond it).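

For the compounds shown here, compound 1 and compound 3 give the first pair that differs only at this position: in this assay, the change from 4-chlorophenyl to phenyl is a number 15.5 percentage points higher from compound 1 to compound 3 (beyond the scatter), a modest step toward a weaker effect. The chloro on this aromatic carbon therefore makes a measurable difference in this series, at least against hydrogen. Nothing available accounts for this step.

On these data alone, it remains open whether another group on this carbon, such as bromo or a carboxylic acid, would match chloro or fall closer to hydrogen. As far as these compounds go, the same change on the second 4-chlorophenyl group of compound 1 also remains open.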